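The source may report more compounds than this note shows. Statements on the series, on what has been measured and on what is new or still open speak of the compounds shown alone.

Three compounds have been measured so far in an assay on isolated protein for inhibition of Amine oxidase [flavin-containing] B (Homo sapiens), read by fluorescence and spectrophotometry; on this read-out higher numbers stand for weaker inhibition and lower numbers for stronger inhibition:

Compound 1 `O=C(NCc1cnnn1Cc1ccc2oc(-c3ccc(Cl)cc3)cc(=O)c2c1)c1ccccc1` — 32900 nM
Compound 2 `Cc1ccc(NC(=O)CCCCc2cn(Cc3ccc4oc(-c5ccc(Cl)cc5)cc(=O)c4c3)nn2)cc1` — 32900 nM
Compound 3 `O=C(CCc1cn(Cc2ccc3oc(-c4ccc(Cl)cc4)cc(=O)c3c2)nn1)Nc1ccccc1` — 32900 nM

All three share the same core and differ only in the chain and the amide end that hang from the triazole. On the numbers shown, compound 2 stands level with compound 1 and with compound 3; none of the three is set apart from the others beyond the scatter of this assay.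

The next compound, compound 4 `O=C(CCCCc1cn(Cc2ccc3oc(-c4ccc(Cl)cc4)cc(=O)c3c2)nn1)Nc1ccccc1`, is reached from compound 2 by a single change: hydrogen in place of methyl on an aromatic carbon.

For the measured compounds named here, one measured step bears on this. From compound 2 to compound 3 the amide end was changed and the chain shortened, and this gave no change at the digits printed from compound 2 to compound 3 (within the scatter). Since reshaping that same end of the molecule left the value where it was, the smaller change from compound 2 to compound 4 is expected to leave it there as well, that is, a step of no change at the digits printed from compound 2 to compound 4 (within the scatter) is expected. Compound 4 is therefore estimated at 32900 nM, with a range from 15000 nM to 70000 nM.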

Compound 4, half-maximal inhibitory concentration: 32900 nM
Estimate against measurement, compound 4: no gap at the digits printed; measured number inside the range.
By their numbers in this assay, from the lowest: compounds 1, 2, 3 and 4 (each within the scatter of the next).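

In this assay, replacing the methyl of the 4-methylphenyl end with hydrogen, which leaves a plain phenyl, gives no change at the digits printed from compound 2 to compound 4 (within the scatter). For the compounds shown here, this is the first step here that touches that one spot alone, and at this aromatic carbon, para to a large group, methyl and hydrogen cannot be told apart. With the phenyl end now held constant, 2-(phenylcarbamoyl)ethyl in place of phenylcarbamoyl gives no change at the digits printed from compound 3 to compound 4 (within the scatter), so that difference in the chain also leaves the value within the scatter.

Still open, on these data alone, is whether a larger or different group at that ring carbon, such as methoxy or a carboxylic acid, or an amine in place of the amide, would move the value from the figure all four compounds share. Nothing available explains why these values coincide.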